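Adding one carbon to an ether chain

The compounds below may be only part of what the source reports. "The series", "measured", "known", "first", "only" and "open" are said of these compounds alone.

In an in vivo ADME assay on the whole organism (strain CD1) for pharmacokinetics, with Mus musculus as the target, at a dose of 200 mg/kg by the oral route (on this read-out lower numbers stand for lower exposure and higher numbers for higher exposure at the dose given), compound 1 (`CCOC(=O)c1c(-c2cccc(-c3ccccc3)c2)[nH]c2cc(OC)ccc2c1=O`) gives 430 nM and compound 2 (`CCOC(=O)c1c(-c2cccc(OC)c2)[nH]c2cc(OC)ccc2c1=O`) gives 5800 nM while compound 3 (`CCOC(=O)c1c(-c2cccc(OCC)c2)[nH]c2cc(OC)ccc2c1=O`) stands second highest of the three at 2400 nM. Compound 4 (`CCCOc1cccc(-c2[nH]c3cc(OC)ccc3c(=O)c2C(=O)OCC)c1`) changes ethoxy to propoxy (methyl in place of hydrogen on a saturated chain carbon, two bonds along the chain from an oxygen on an aromatic ring), which places methyl in place of hydrogen on a saturated chain carbon. Among the compounds with values here, the closest precedent is the one-carbon extension of methoxy to ethoxy (a 2.4-fold lower number from compound 2 to compound 3 (0.38 log units; beyond the scatter)), a modest step. Replacing phenyl gave larger steps (a 13-fold higher number from compound 1 to compound 2 (1.13 log units; beyond the scatter); a 5.6-fold higher number from compound 1 to compound 3 (0.75 log units; beyond the scatter)), but that is a different change. Within the data shown here, only one comparable step exists, so the expectation is loose: a further modest fall (a 2.2-fold lower number from compound 3 to compound 4 (0.34 log units; beyond the scatter)) is expected. For compound 4 the estimate is 1100 nM within an expected range (400 nM to 2800 nM).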

Compound 4, maximal plasma concentration: 1800 nM
The estimate for compound 4 lay 1.6-fold (0.21 log units) below the measured number; the measured number falls inside the stated range.
By their numbers in this assay, from the lowest: compound 1; then compounds 4 and 3 (each within the scatter of the next); then compound 2.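

In this assay, lengthening ethoxy to propoxy gives a 1.3-fold lower number from compound 3 to compound 4 (0.12 log units; within the scatter), so this added carbon, unlike the one added to methoxy, makes no readable difference. Even so, the longer chain leaves a clear gap to the methoxy compound, with a 3.2-fold lower number from compound 2 to compound 4 (0.51 log units; beyond the scatter). Propoxy also joins methoxy and ethoxy in beating phenyl at this place, with a 4.2-fold higher number from compound 1 to compound 4 (0.62 log units; beyond the scatter).

No supporting data explain these numbers. Going by these compounds, whether a longer chain such as butoxy, or a chain ending in an amine, would stay level with propoxy remains open.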